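Urea nitrogen substituent swap in a bicyclic oxadiazole series

A few compounds are considered here, and "the series" means these few. Any claim that something is new, unique, unknown or untested is made for them only; others in the source may bear on it.

Measured compounds in a functional assay on Shh Light II cells (Mus musculus) for inhibition, read by a luciferase reporter; on this read-out higher numbers stand for weaker inhibition and lower numbers for stronger inhibition:
compound 1 `COc1ccccc1NC(=O)N1CCC(c2nc(-c3ccc4ccccc4n3)no2)CC1` gives 410 nM
compound 2 `O=C(NC1CCCCC1)N1CCN(c2nc(-c3ccc4ccccc4n3)no2)CC1` gives 53 nM
compound 3 `COc1ccccc1N(C)C(=O)N1CCC(c2nc(-c3ccc4ccccc4n3)no2)CC1` gives 3100 nM

Compound 1 stands second highest of the three numbers. Its nearest neighbour is compound 3, reached by methyl in place of hydrogen on an amide-type nitrogen: a 7.6-fold higher number from compound 1 to compound 3 (0.88 log units; beyond the scatter). Compound 2, which differs from compound 1 in more than one place, sits furthest away, with the lowest number of the three.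

Compound 4 `CC(=O)N1CCC(NC(=O)N2CCC(c3nc(-c4ccc5ccccc5n4)no3)CC2)CC1` is the next member to be measured in this assay. It differs from compound 1 as follows: 1-acetylpiperidin-4-yl in place of 2-methoxyphenyl on an amide-type nitrogen. Going by the values given here, the only measured step, the methylation from compound 1 to compound 3, does not touch the group exchanged here and so does not bear on this change directly; it shows only that the amide hydrogen on that nitrogen is retained in compound 4. Compound 2 carries a saturated six-membered ring on the same nitrogen and gives the lowest number, but its second difference to compound 1 prevents a clean reading.

On these grounds a modest step downward is expected for compound 4, a 2.1-fold lower number from compound 1 to compound 4 (0.31 log units; beyond the scatter), with the wide range reflecting the lack of a matched pair. The estimate for compound 4 is 200 nM, between 50 nM and 800 nM.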

Compound 4, half-maximal inhibitory concentration: 500 nM
Beside the measured number, compound 4's estimate is 2.5-fold (0.40 log units) below it; measured number inside the range.
By their numbers in this assay, from the lowest: compound 2; then compounds 1 and 4 (each within the scatter of the next); then compound 3.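

In this assay, 1-acetylpiperidin-4-yl in place of 2-methoxyphenyl on the amide-type nitrogen gives a 1.2-fold higher number from compound 1 to compound 4 (0.09 log units; within the scatter), so at this position the non-aromatic ring with its acetyl group and the aromatic ring with its methoxy group are not separated by this read-out. The second new step, a 6.2-fold lower number from compound 3 to compound 4 (0.79 log units; beyond the scatter), exchanges (2-methoxyphenyl)(methyl)amino for (1-acetylpiperidin-4-yl)amino on a carbonyl carbon, and it leaves compound 3 alone at the high end, with compounds 1 and 4 both carrying the amide hydrogen and reading alike. No measurement at hand accounts for the two different groups giving matching numbers.

Open, as far as these compounds go, is how a cyclohexyl group or a piperidin-4-yl group with a free ring amine would read on this nitrogen with the core of compound 1, which would show whether the low number of compound 2 belongs to its nitrogen substituent or to its other difference. Also open, from the compounds shown here alone, is whether methyl on the amide-type nitrogen of compound 4 would shift the number as it does in the step of a 7.6-fold higher number from compound 1 to compound 3 (0.88 log units; beyond the scatter).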